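A few compounds are considered here, and "the series" means these few. Any claim that something is new, unique, unknown or untested is made for them only; others in the source may bear on it.

Measured so far in a functional assay on A549 cells (Homo sapiens) for antiproliferative activity, read by sulforhodamine B assay, with a stated time of 3 days; on this read-out lower numbers stand for stronger inhibition of growth and higher numbers for weaker inhibition of growth:
compound 1 `O=C(Nc1nccs1)c1cccc(Nc2ncc(F)c(Nc3ccc(F)cc3)n2)c1`: > 10000 nM (a limit)
compound 2 `COc1ccc(NC(=O)c2cccc(Nc3ncc(F)c(Nc4ccc(F)cc4)n3)c2)cc1`: 11000 nM
compound 3 `O=C(Nc1cccc(Nc2ncc(F)c(Nc3ccc(F)cc3)n2)c1)c1ccccc1`: 37800 nM

Compound 2 holds the lower of the two actual numbers in this assay. Compound 1 gives only a limit, so it cannot be ranked against the others.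

The next compound to be read is compound 4 `COc1cc(NC(=O)c2cccc(Nc3ncc(F)c(Nc4ccc(F)cc4)n3)c2)cc(OC)c1`. Its change from compound 2 is 3,5-dimethoxyphenyl in place of 4-methoxyphenyl on an amide-type nitrogen. For the measured compounds named here, no measured compound carries this group.

Going by the values given here, two measured steps bear on the change, and neither gives a direct guide. The step at the same place is a step that the limit leaves unreadable from compound 1 to compound 2. Among the compounds with values here, the only readable step is a 3.4-fold higher number from compound 2 to compound 3 (0.54 log units; beyond the scatter), but it replaces the whole (4-methoxyphenyl)carbamoyl with benzamido, a larger change than the one in compound 4. Together they give no direction for the new step, and its central expectation in this assay is none beyond the scatter.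

The estimated outcome is a 1.1-fold lower number from compound 2 to compound 4 (0.04 log units; within the scatter). Compound 4 is expected at 10000 nM, with an estimated range of 3500 nM to 30000 nM.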

Compound 4, concentration for 50% growth inhibition: 13900 nM
Estimate against measurement, compound 4: 1.4-fold (0.14 log units) below, within the range that was stated.
By their numbers in this assay, from the lowest: compounds 2 and 4 (each within the scatter of the next); then compound 3.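

In this assay, for the compounds shown here, putting 3,5-dimethoxyphenyl in place of 4-methoxyphenyl on the amide-type nitrogen gives a 1.3-fold higher number from compound 2 to compound 4 (0.10 log units; within the scatter), the first readable step that changes only the group on this nitrogen and keeps the carbonyl link in place. Within this pair, the larger group with its added oxygen leaves the read-out within the scatter, so the assay does not separate these two methoxy-bearing aryl groups. Compound 1 gives only a limit, and the steps from compound 1 cannot be read: the limit of > 10000 nM in this assay, at which 1 of the 4 values shown sits.

As far as these compounds go, two methoxy-bearing aryl groups say little about this position as a whole, so it remains open whether a dimethylamino group or a carboxylic acid on the aryl ring would shift the number beyond the scatter. Going by these compounds alone, also open is whether the tolerance seen here extends to a longer chain set between the amide-type nitrogen and the aryl ring, or holds for any change at this place other than the one read in compound 2 and compound 4.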